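Trifluoromethyl for Fluoro, Moved to a Second Core

This account rests on a few compounds, and the source may have more. Where it says the series, first, only, none or still open, it means among the compounds named here.

Compound 1 `Oc1cccc2[nH]c(-c3ccc(-c4ccc(-c5ccc(F)cc5)cc4)cc3)nc12` and compound 2 `Oc1cccc2[nH]c(-c3ccc(-c4ccc(-c5ccc(C(F)(F)F)cc5)cc4)cc3)nc12` share one core, while compound 3 `Cc1ccc2[nH]c(-c3ccc(-c4ccc(-c5ccc(F)cc5)cc4)cc3)nc2c1` and compound 4 `Cc1ccc2[nH]c(-c3ccc(-c4ccc(-c5ccc(C(F)(F)F)cc5)cc4)cc3)nc2c1` share another; the difference between the two cores is not broken down here. In a functional assay on SiHa cells (Homo sapiens) for inhibition, read by sulforhodamine B assay (on this read-out higher numbers stand for weaker inhibition of growth and lower numbers for stronger inhibition of growth), compound 1 gives 9100 nM, compound 2 gives 3720 nM and compound 3 gives 41000 nM. The change from compound 1 to compound 2 is trifluoromethyl in place of fluoro on an aromatic carbon, and it produced a 2.4-fold lower number from compound 1 to compound 2 (0.39 log units; beyond the scatter). Compound 4 carries the same change on the other core, (trifluoromethyl in place of fluoro on an aromatic carbon), at a place described in exactly the same words. Within the data shown here, only one earlier instance of this change is known, so the expectation for compound 4 leans on it: compound 4 is expected to show a 2.4-fold lower number from compound 3 to compound 4 (0.38 log units; beyond the scatter) because the same change gave a 2.4-fold lower number from compound 1 to compound 2 (0.39 log units; beyond the scatter). The estimate for compound 4 in this assay is 17000 nM, with a range from 8000 nM to 40000 nM.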

Compound 4, concentration for 50% growth inhibition: 33200 nM
For compound 4 the middle estimate is 2.0-fold (0.29 log units) below the measured one, within the range that was stated.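

On the second core, the same change gives a 1.2-fold lower number from compound 3 to compound 4 (0.09 log units; within the scatter) in this assay, so the clear shift seen on the first core is not reproduced as a clear shift here. Even so, the two steps cannot be told apart: the same change on two cores in this assay, a 2.4-fold lower number (0.39 log units; beyond the scatter) from compound 1 to compound 2 and a 1.2-fold lower number (0.09 log units; within the scatter) from compound 3 to compound 4, 2.0-fold (0.30 log units) apart, within the scatter of two such steps This shows no measured difference between the two cores for this change, but with only one pair on each core it does not show that the effect is truly the same on both, and the step between the cores themselves, an 8.9-fold higher number from compound 2 to compound 4 (0.95 log units; beyond the scatter), is larger than either.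

From the compounds shown here alone, whether an amine or a carboxylic acid in place of the fluoro would behave alike on both cores stays open. So does whether trifluoromethyl for fluoro would give a similar step on any further core.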